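Restoring an Aromatic Ring on the Sulfur-Bound Chain

This account rests on a few compounds, and the source may have more. Where it says the series, first, only, none or still open, it means among the compounds named here.

Three compounds share one core and differ only in the group carried on a saturated chain carbon bound to a sulfur. In a functional assay on PC-9 cells (Homo sapiens) for inhibition, read by MTT assay, with a stated time of 72 h (a higher number here means a weaker inhibitor, a lower number a stronger inhibitor), compound 1 `Cc1cc(Nc2cc(-c3ccccc3)[nH]n2)n2nc(SCCCc3ccccc3)nc2n1` gives 5030 nM, and compound 2 `Cc1cc(Nc2cc(-c3ccccc3)[nH]n2)n2nc(SCc3ccc(Cl)cc3)nc2n1` gives 6710 nM. Compound 3 `Cc1cc(Nc2cc(-c3ccccc3)[nH]n2)n2nc(SCC3CC3)nc2n1` reaches only the limit of this assay, > 50000 nM. Compound 3 therefore stands at the limit of > 50000 nM in this assay, at which 1 of the 3 values shown sits, the weak end of the numbers shown.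

Compound 4 `COc1ccc(CSc2nc3nc(C)cc(Nc4cc(-c5ccccc5)[nH]n4)n3n2)cc1` has not yet been measured. 4-methoxyphenyl in place of cyclopropyl on a saturated chain carbon bound to a sulfur The measured steps that bear on this change both run in the opposite direction: an at least 9.9-fold higher number from compound 1 to compound 3 (0.99 log units; beyond the scatter) and an at least 7.4-fold higher number from compound 2 to compound 3 (0.87 log units; beyond the scatter). In each case exchanging a phenyl-bearing group for cyclopropyl weakened inhibition at least modestly, so putting an aromatic ring back is expected to reverse that, with a sizable fall in the number. Compound 2, which carries 4-chlorophenyl at the same place, is the closest measured neighbour and offers a guide to the likely level. Compound 4 is therefore estimated at 7000 nM in this assay, with a range from 3000 nM to 20000 nM. For compound 4 this estimate means an expected step of an at least 7.1-fold lower number from compound 3 to compound 4 (0.85 log units; beyond the scatter).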

Compound 4, half-maximal inhibitory concentration: 8110 nM
For compound 4 the middle estimate is 1.2-fold (0.06 log units) below the measured one; low and high end bracket the measured number.
By their numbers in this assay, from the lowest: compounds 1, 2 and 4 (each within the scatter of the next). At a limit, above all of these: compound 3.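

In this assay, 4-methoxyphenyl in place of cyclopropyl on a saturated chain carbon bound to a sulfur gives an at least 6.1-fold lower number from compound 3 to compound 4 (0.78 log units; beyond the scatter), so a third aromatic group at this place, now with methoxy on its ring, separates from the cyclopropyl compound beyond the scatter. Methoxy in place of chloro on an aromatic carbon gives a 1.2-fold higher number from compound 2 to compound 4 (0.08 log units; within the scatter), and 4-methoxyphenyl in place of phenethyl gives a 1.6-fold higher number from compound 1 to compound 4 (0.21 log units; within the scatter), so in this set neither the swap of these two ring groups nor the difference between the 4-methoxyphenyl and phenethyl groups moves the number beyond the scatter. Compound 3 remains a limit of the assay and not a number, so the step from it is a bound: the limit of > 50000 nM in this assay, at which 1 of the 4 values shown sits.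

As far as these compounds go, what stays open is whether an amine or a carboxylic acid on the same aromatic ring would hold the number at this level or shift it beyond the scatter. From the compounds shown here alone, it is also open whether the ring has to be aromatic at all, as a cyclohexyl group at this place would test, and whether a longer chain would change the picture.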